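Unsaturation in the Side Chain of Compound 1

This account rests on a few compounds, and the source may have more. Where it says the series, first, only, none or still open, it means among the compounds named here.

Compound 1, `CCCC[C@H](CC)C[C@]1(CC)C=C(CC)/C(=C/C(=O)OC)O1`: in a functional assay on Bel-7402 cells (Homo sapiens) for cytotoxicity, read by MTT assay, with a stated time of 72 h (a higher number here means a weaker inhibitor, a lower number a stronger inhibitor), compound 1 gives only a limit, > 100000 nM.
Compound 2, `CCCCC(C)C[C@]1(CC)O[C@H]1[C@]1(CC)C=CC(=O)O1`: in this assay compound 2 gives only a limit, > 100000 nM.
Compound 3, `CCCCC(C)C/C(=C/[C@@]1(CC)OC(=O)C[C@@H]1O)CC`: in this assay compound 3 gives only a limit, > 100000 nM.

Compound 1 stands nowhere in particular within this set: no number is known for it, only a limit, and the same holds for compound 2 and compound 3, so no order among the three can be read from this assay. What unites them is recorded in the limit of > 100000 nM in this assay, at which 3 of the 3 values shown sit.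

Within the data shown here, compound 4, `CC/C=C/[C@H](CC)C[C@]1(CC)C=C(CC)/C(=C/C(=O)OC)O1`, is the one compound still to be measured. It departs from compound 1 at a single site: but-1-en-1-yl in place of butyl on a saturated chain carbon bound to two saturated chain carbons. The rest of the molecule is kept as it is.

Among the measured compounds shown here, since no measured pair differs in one place, the size of this step cannot be read from any pair that has been run. For the measured compounds named here, the only anchor is compound 1 itself, which sits at the limit. From that anchor, the expected change from compound 1 to compound 4 in this assay is a number no higher from compound 1 to compound 4 (the limit leaves the size open), which is to say none that would stand out from the scatter. Compound 4 is therefore estimated at 100000 nM, with a range from 40000 nM to 300000 nM, and most likely it will again return only a limit.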

Compound 4, half-maximal inhibitory concentration: > 100000 nM
Compound 4 ended at the assay's limit; the forecaster's own chance of this, stated with the estimate: 85%; the middle value sits exactly at the limit.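

No new step can be read: compound 1 and compound 4 both return only a limit in this assay, so the change from butyl to but-1-en-1-yl has no readable size, and the set as a whole gives no number: the limit of > 100000 nM in this assay, at which 4 of the 4 values shown sit.

The compounds shown leave open whether any change to the side chain or the shared core would yield a measured value in this assay rather than a limit.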